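From 4-nitrophenyl to 4-chlorophenyl: a small step expected

This account rests on a few compounds, and the source may have more. Where it says the series, first, only, none or still open, it means among the compounds named here.

Among the measured compounds shown here, in a functional assay on cells (Erythrocyte, Homo sapiens) for inhibition, read by spectrophotometry and hemolysis, with a stated time of 10 min (a higher number here means a weaker inhibitor, a lower number a stronger inhibitor), two compounds carry numbers so far. Compound 1 (`O=C(CCCc1nc2ccccc2c(=O)[nH]1)N/N=C/c1cc(O)c(O)c(O)c1`) gives 183000000 nM and compound 2 (`O=C(CCCc1nc2ccccc2c(=O)[nH]1)N/N=C/c1ccc([N+](=O)[O-])cc1`) gives 52000000 nM as the lower of the two numbers, which makes it the stronger inhibitor of the pair.

Compound 3 (`O=C(CCCc1nc2ccccc2c(=O)[nH]1)N/N=C/c1ccc(Cl)cc1`) keeps the shared core and differs from compound 2 in one group: chloro in place of nitro on an aromatic carbon, para to a large group (chloro in place of nitro on an aromatic carbon).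

For the measured compounds named here, only one measured step bears on this change, and only loosely, as it concerns the same place: a 3.5-fold lower number from compound 1 to compound 2 (0.55 log units; beyond the scatter) is modest and beyond the scatter. Going by the values given here, no measured compound carries chloro, so the data do not fix a direction.

A step no larger than that one is expected, probably within the scatter, with a slight lean to a higher number as compound 2 at (52000000 nM) marks the low end of the series. The estimated step runs (a 1.4-fold higher number from compound 2 to compound 3 (0.16 log units; within the scatter)).

In this assay compound 3 is expected at 75000000 nM with a range from 28000000 nM to 190000000 nM as an estimate.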

Compound 3, half-maximal inhibitory concentration in the Erythrocyte assay: 67000000 nM
Estimate against measurement, compound 3: 1.1-fold (0.05 log units) above; low and high end bracket the measured number.
By their numbers in the Erythrocyte assay, from the lowest: compounds 2 and 3 (each within the scatter of the next); then compound 1.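

In the Erythrocyte assay, chloro and nitro at this place, on an aromatic carbon para to a large group, are not told apart (a 1.3-fold higher number from compound 2 to compound 3 (0.11 log units; within the scatter)). a physicochemical assay, read by spectrophotometry, with a stated time of 30 min (on this read-out lower numbers stand for stronger inhibition and higher numbers for weaker inhibition), gives the same reading (a 1.1-fold higher number from compound 2 to compound 3 (0.05 log units; within the scatter)), with compound 2 at 316000000 nM and compound 3 at 353000000 nM, so the two groups stand level in both read-outs. In the Erythrocyte assay, the separation from the trihydroxyphenyl compound also holds with the new group (a 2.7-fold lower number from compound 1 to compound 3 (0.44 log units; beyond the scatter)), which shows that it does not depend on nitro alone and is shared by 4-nitrophenyl and 4-chlorophenyl. No evidence on the properties of these groups accompanies these numbers, so the match between them stands only as an observation.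

As far as these compounds go, whether an amine, a methoxy group or a carboxylic acid at this place would stay level with compounds 2 and 3 or separate from them remains open. Also open is whether a longer chain between the shared core and the hydrazone-bearing end would change the picture, since all three compounds shown carry the same chain.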